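This account rests on a few compounds, and the source may have more. Where it says the series, first, only, none or still open, it means among the compounds named here.

Of the compounds shown here, two of a shared core have been measured in an assay on CHO cells for displacement of a labelled ligand from adenosine receptor A3 (Homo sapiens); a higher number here means a weaker inhibitor, a lower number a stronger inhibitor. Compound 1 `O=C(Nc1ncc(C(=O)O)c2nc(-c3ccco3)nn12)NC1CCCCC1` gives 59400 nM, and compound 2 `O=C(O)c1cnc(NCc2ccc(F)cc2)n2nc(-c3ccco3)nc12` gives 14000 nM, the lowest of the two numbers; the step of a 4.2-fold lower number from compound 1 to compound 2 (0.63 log units; beyond the scatter) separates them. Compound 3 `O=C(O)c1cnc(NCc2ccc(Cl)cc2)n2nc(-c3ccco3)nc12` differs from compound 2 by chloro in place of fluoro on an aromatic carbon. Among the compounds with values here, no measured step concerns this change, since the only step on record, from compound 1 to compound 2, replaces a different group, so the direction of the new step cannot be read from it. Compound 3 is expected to sit near compound 2 in this assay, with the step of a 1.6-fold lower number from compound 2 to compound 3 (0.19 log units; within the scatter) estimated as small, giving an estimate of 9000 nM within a range of 3000 nM to 30000 nM.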

Compound 3, inhibition constant: 11600 nM
For compound 3 the middle estimate is 1.3-fold (0.11 log units) below the measured one; the range from low to high includes it.
By their numbers in this assay, from the lowest: compounds 3 and 2 (each within the scatter of the next); then compound 1.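

In this assay, chloro can stand in place of fluoro on the benzyl group with a 1.2-fold lower number from compound 2 to compound 3 (0.08 log units; within the scatter) and so this exchange leaves the number effectively unchanged. The 4-chlorobenzyl group also shows a 5.1-fold lower number from compound 1 to compound 3 (0.71 log units; beyond the scatter) and so the advantage over cyclohexylcarbamoyl seen with 4-fluorobenzyl holds for a second halogen. The evidence at hand offers no explanation for either step. The compounds shown leave open how an unsubstituted benzyl group, or a bromo or methoxy group on that aromatic carbon, would behave. They also leave open what an ester or amide in place of the carboxylic acid would do.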